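A few compounds are considered here, and "the series" means these few. Any claim that something is new, unique, unknown or untested is made for them only; others in the source may bear on it.

Measured in a functional assay on NTUB1 cells (Homo sapiens) for cytotoxicity, read by MTT assay, with a stated time of 72 h; a higher number here means a weaker inhibitor, a lower number a stronger inhibitor:
- compound 1 `COc1ccc(OC)c(C(=O)/C=C/c2ccc(C(=O)OCc3ccccc3)cc2)c1` gives 13300 nM
- compound 2 `COc1ccc(OC)c(C(=O)/C=C/c2ccc(C(=O)NC(C)C)cc2)c1` gives 1970 nM

Compound 2 has the lower number of the two. Compound 3 `COc1ccc(OC)c(C(=O)/C=C/c2ccc(C(=O)N(C)C)cc2)c1` carries dimethylamino in place of isopropylamino on a carbonyl carbon. Among the compounds with values here, the one measured step at this place (a 6.8-fold lower number from compound 1 to compound 2 (0.83 log units; beyond the scatter)) was modest, though beyond the scatter, and it brought in isopropylamino for benzyloxy, a different change, so it guides the size only loosely. Within the data shown here, a step of similar or smaller size is expected, more likely upward, as compound 2 holds the lowest number so far. The estimate amounts to a 1.4-fold higher number from compound 2 to compound 3 (0.15 log units; within the scatter) in this assay. For compound 3 the expected value is 2800 nM (range 1000 nM to 8000 nM).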

Compound 3, half-maximal inhibitory concentration: 3890 nM
Beside the measured number, compound 3's estimate is 1.4-fold (0.14 log units) below it; low and high end bracket the measured number.
By their numbers in this assay, from the lowest: compounds 2 and 3 (each within the scatter of the next); then compound 1.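

In this assay, replacing isopropylamino with dimethylamino gives a 2.0-fold higher number from compound 2 to compound 3 (0.30 log units; within the scatter), so losing the amide hydrogen moves the number by no more than the scatter. Dimethylamino, like isopropylamino, also departs from benzyloxy, with a 3.4-fold lower number from compound 1 to compound 3 (0.53 log units; beyond the scatter), so this drop is not confined to a single amino group. No measurement here gives an explanation for these numbers. Left open is how an unsubstituted amino group, a longer alkylamino chain or a carboxylic acid on this carbonyl carbon would compare.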